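The source may report more compounds than this note shows. Statements on the series, on what has been measured and on what is new or still open speak of the compounds shown alone.

Measured so far:
- compound 1, `COc1ccc(C2CC(c3ccc(OCc4cn(Cc5ccc([N+](=O)[O-])cc5)nn4)cc3)=NN2C(C)=O)cc1`: 4%
- compound 2, `COc1cc(C2CC(c3ccc([N+](=O)[O-])cc3)=NN2C(C)=O)ccc1OCc1cn(Cc2ccc([N+](=O)[O-])cc2)nn1`: 33%

In a functional assay on COLO 205 cells (Homo sapiens) for inhibition, read by sulforhodamine B assay, tested at 10 uM (a higher number here means more inhibition of growth at the concentration tested, a lower number less inhibition of growth), compound 2 gives 33%. Within the data shown here, of the two numbers so far it stands highest; its nearest neighbour is compound 1, which in this assay gives 4%, a gap that lies beyond the usual scatter. Among the measured compounds shown here, the two compounds differ in more than one place, so the pair shows only that compound 2 inhibits growth more strongly than compound 1 at the tested concentration.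

Compound 3, `COc1cc(C2CC(c3ccccc3)=NN2C(C)=O)ccc1OCc1cn(Cc2ccc([N+](=O)[O-])cc2)nn1`, has not yet been measured. It is derived from compound 2 by one change, (hydrogen in place of nitro on an aromatic carbon); cut one bond further out, the same difference reads 4-nitrophenyl to phenyl. For the measured compounds named here, no pair of measured compounds shows this exact change, so the direction of the step rests on what the two values above suggest: the compound carrying the nitro group is the stronger one, and taking it away is expected to cost some inhibition. The step from compound 2 to compound 3 is expected to be a number 18 percentage points lower from compound 2 to compound 3 (beyond the scatter). For compound 3 the estimate is 15%, between 0% and 35%.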

Compound 3, percent growth inhibition at one concentration: 7%
Compound 3: the middle estimate sits 8 percentage points above what was measured; the range from low to high includes it.
By their numbers in this assay, from the lowest: compounds 1 and 3 (each within the scatter of the next); then compound 2.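

In this assay, among these compounds, the change from 4-nitrophenyl to phenyl provides the first comparison in which only one place differs, and it gives a number 26 percentage points lower from compound 2 to compound 3 (beyond the scatter). The earlier pair differed in more than one place and could not tie its gap to any single group, whereas here a drop beyond the scatter follows the loss of the nitro group alone, on an aromatic carbon para to a large group, with the rest of the molecule unchanged. Nothing available explains why removing the nitro group at this position has this effect.

The compounds shown leave open whether the nitro group is specifically required here or whether another group in the same place, such as an amine, a nitrile or a carboxylic acid, would preserve the inhibition seen with compound 2. They also leave open what the other nitro group, which compound 2 and compound 3 both carry, contributes, since no comparison shown changes that group alone.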